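From Acetamide to 4-Fluorobenzamide on a Shared Core

A few compounds are considered here, and "the series" means these few. Any claim that something is new, unique, unknown or untested is made for them only; others in the source may bear on it.

Compound 2 `COc1ccc(S(=O)(=O)N2CCc3cccc(NC(C)=O)c32)cc1` carries an acetamido group on the shared core, and in a functional assay on MKN-45 cells (Homo sapiens) for cytotoxicity (on this read-out higher numbers stand for weaker inhibition and lower numbers for stronger inhibition), compound 2 gives 61 nM. Among the two numbers known so far this is the lowest, yet compound 1 `COc1ccc(S(=O)(=O)N2CCc3cccc(NC(=O)c4ccc(C#N)cc4)c32)cc1`, which in this assay gives 89 nM, lies within the scatter of it, the step being a 1.5-fold lower number from compound 1 to compound 2 (0.16 log units; within the scatter). Compound 3 `COc1ccc(S(=O)(=O)N2CCc3cccc(NC(=O)c4ccc(F)cc4)c32)cc1` remains to be measured. It differs from compound 2 in a single place: 4-fluorophenyl in place of methyl on a carbonyl carbon. Among the measured compounds shown here, only one measured step bears on this change, the one in which methyl took the place of 4-cyanophenyl on the same carbonyl carbon, and its result was a 1.5-fold lower number from compound 1 to compound 2 (0.16 log units; within the scatter), a difference within the scatter. With an aryl group once more entering in place of methyl, no shift beyond the scatter in this assay is expected, and compound 3 should sit close to compounds 1 and 2. Compound 3 is therefore estimated at 75 nM, with a range from 30 nM to 190 nM. The step this estimate means is expected to be a 1.2-fold higher number from compound 2 to compound 3 (0.09 log units; within the scatter).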

Compound 3, half-maximal inhibitory concentration: 45 nM
For compound 3 the middle estimate is 1.7-fold (0.22 log units) above the measured one; the range from low to high includes it.
By their numbers in this assay, from the lowest: compounds 3, 2 and 1 (each within the scatter of the next).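

In this assay, 4-fluorophenyl in place of methyl on a carbonyl carbon gives a 1.4-fold lower number from compound 2 to compound 3 (0.13 log units; within the scatter), so a group with one six-membered aromatic ring and a lone methyl remain within the scatter of each other at this place on the shared core. The earlier step had shown this for 4-cyanophenyl, and the new pair adds the first comparison in which only the substituent on the aromatic ring differs: fluoro in place of cyano on an aromatic carbon gives a 2.0-fold lower number from compound 1 to compound 3 (0.30 log units; within the scatter), again printed as within the scatter, so methyl, 4-cyanophenyl and 4-fluorophenyl are not told apart by this read-out. No measurement at hand offers an explanation for this.

As far as these compounds go, whether the position stays this accommodating for other kinds of group remains open, for example an amine or a carboxylic acid on the aromatic ring, or a longer alkyl chain on the carbonyl carbon. From the compounds shown here alone, all three compounds also keep the amide hydrogen, so what a methyl group on that amide nitrogen would do is unknown.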